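Removing the Hydroxy Group from Compound 1

A few compounds are considered here, and "the series" means these few. Any claim that something is new, unique, unknown or untested is made for them only; others in the source may bear on it.

Of the compounds shown here, three sharing one core have been measured in a physicochemical assay for solubility, read by HPLC, at pH 2; a lower number here means a less soluble compound, a higher number a more soluble compound. Compound 1 `OC1CC2(CCN(CCC3CCCCC3)CC2)Oc2c1ccc1ccccc21` gives 40000 nM, the highest of the three numbers. Compound 2 `O=C1CC2(CCN(CCC3CCCCC3)CC2)Oc2c1ccc1ccccc21` gives 20000 nM, and compound 3 `CCN1CCC2(CC1)CC(O)c1ccc3ccccc3c1O2` gives 20000 nM. Both of these lie within the scatter of compound 1, so the three values cannot be told apart with confidence. Within the data shown here, the one single-point step among them, a 2.0-fold lower number from compound 1 to compound 3 (0.30 log units; within the scatter), shows that exchanging the cyclohexyl group for a hydrogen on the chain leaves the number essentially where it was.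

Compound 4 `c1ccc2c3c(ccc2c1)CCC1(CCN(CCC2CCCCC2)CC1)O3` has not yet been measured. It differs from compound 1 in one place: hydrogen in place of hydroxy on a saturated ring carbon. Among the measured compounds shown here, no measured step removes a hydroxy group, so none bears directly on this change. For the measured compounds named here, the only guidance is that the single change studied so far, the one to compound 3, stayed inside the scatter, and that compound 2 also sits close to compound 1. On that basis compound 4 is expected to land near compound 1, perhaps slightly lower, a step of about a 2.0-fold lower number from compound 1 to compound 4 (0.30 log units; within the scatter). The estimate for compound 4 is 20000 nM, with an expected range from 7000 nM to 60000 nM.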

Compound 4, solubility: 40000 nM
Compound 4: the middle estimate sits 2.0-fold (0.30 log units) below what was measured; low and high end bracket the measured number.
By their numbers in this assay, from the lowest: compounds 2, 3, 1 and 4 (each within the scatter of the next).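

In this assay, the saturated ring carbon three ring bonds from the ring oxygen now has a direct test: replacing its hydroxy group, and with it a hydrogen-bond donor and a hydrogen-bond acceptor, by hydrogen gives no change at the digits printed from compound 1 to compound 4 (within the scatter). The earlier compounds changed this carbon only through the carbonyl of compound 2, and the one listed step concerned the chain on the amine nitrogen, so hydrogen at this carbon is new information. This carbon has now been seen with hydroxy in compound 1, carbonyl in compound 2 and hydrogen in compound 4, and these three numbers cannot be told apart, although nothing measured here explains that result.

From the compounds shown here alone, what remains open is whether a different group on this carbon, such as an amine or a carboxylic acid, would also stay within the scatter of compound 1, at 40000 nM, in this assay. Going by these compounds, it is also open whether hydrogen in place of hydroxy would read the same on compound 3, which carries hydrogen in place of the cyclohexyl group on the chain.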